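A Halogen for a Methyl on a Weakly Active Core

The source may report more compounds than this note shows. Statements on the series, on what has been measured and on what is new or still open speak of the compounds shown alone.

Three compounds sharing one spirocyclic core were tested in a functional assay on MCF7 cells (Homo sapiens) for antiproliferative activity, read by MTT assay, with a stated time of 48 h; a higher number here means a weaker inhibitor, a lower number a stronger inhibitor. Compound 1 `N#CC1=C(N)Oc2c(c3nc4ccccc4nc3c3ccccc23)C12C(=O)N(Cc1cnnn1-c1ccc(Cl)cc1)c1ccccc12` returns a limit rather than a number, > 50000 nM. Compound 2 `N#CC1=C(N)Oc2c(c3nc4ccccc4nc3c3ccccc23)C12C(=O)N(Cc1cnnn1-c1cccc(S(N)(=O)=O)c1)c1ccccc12` gives 42500 nM. The step of an at least 1.1-fold lower number from compound 1 to compound 2 (0.07 log units; that floor lies within the scatter) lies within the scatter. Compound 3 `Cc1cccc(-n2nncc2CN2C(=O)C3(C(C#N)=C(N)Oc4c(N)cc5nc6ccccc6nc5c43)c3ccccc32)c1` also returns only a limit, > 50000 nM. Where compound 3 stands is thus known only as a limit, and that limit, (the limit of > 50000 nM in this assay, at which 2 of the 3 values shown sit), is the prevailing reading in this set.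

Compound 4 `N#CC1=C(N)Oc2c(N)cc3nc4ccccc4nc3c2C12C(=O)N(Cc1cnnn1-c1cccc(Br)c1)c1ccccc12` differs from compound 3 in one place: bromo in place of methyl on an aromatic carbon. Going by the values given here, the one measured step, an at least 1.1-fold lower number from compound 1 to compound 2 (0.07 log units; that floor lies within the scatter), is a different exchange of the ring on the aromatic nitrogen and stayed within the scatter; no measured step exchanges a group on that aromatic carbon. Since two of three readings sit at the limit (the limit of > 50000 nM in this assay, at which 2 of the 3 values shown sit), compound 4 is expected to remain there as well, with the step of a number no higher from compound 3 to compound 4 (the limit leaves the size open) expected not to exceed the scatter. Compound 4 is therefore estimated at 50000 nM, within 25000 nM to 100000 nM, and most likely reported only as a limit.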

Compound 4, half-maximal inhibitory concentration: > 50000 nM
Compound 4 ended at the assay's limit; the forecaster's own chance of this, stated with the estimate: 65%; the middle value lies on the limit itself.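

Compound 4 returns only a limit in this assay, > 50000 nM, as compound 3 does, so the step from compound 3 to compound 4 cannot be read. The compounds shown leave open whether bromo in place of methyl on that aromatic carbon changes antiproliferative activity at all.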